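A few compounds are considered here, and "the series" means these few. Any claim that something is new, unique, unknown or untested is made for them only; others in the source may bear on it.

Compound 1 `O=C1C(=O)N(CCCCn2cc(COc3cc(=O)oc4ccccc34)nn2)c2ccc(F)cc21` gives 17% in a functional assay on PC-3 cells (Homo sapiens) for inhibition, read by sulforhodamine B assay, with a stated time of 48 h, tested at 50 uM; a lower number here means less inhibition of growth, a higher number more inhibition of growth at the concentration tested.
Compound 2 `O=C1C(=O)N(CCCn2cc(COc3cc(=O)oc4ccccc34)nn2)c2ccc(F)cc21` gives 20% in this assay.
Compound 3 `O=C1C(=O)N(CCCCCn2cc(COc3cc(=O)oc4ccccc34)nn2)c2ccccc21` gives 9% in this assay.

Of the compounds shown here, three sharing a common core have been measured so far, all at one concentration. Compound 1 has the second highest of the three numbers, but the gap to compound 2, the nearest, is within the usual scatter, and so is the larger gap to compound 3, the furthest. On these numbers, therefore, none of the three can be told apart from the others.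

Compound 4 `O=C1C(=O)N(CCCCn2cc(COc3cc(=O)oc4ccccc34)nn2)c2ccc(Cl)cc21` is not yet measured. It differs from compound 1 in one place: chloro in place of fluoro on an aromatic carbon. Among the compounds with values here, no pair among the measured compounds shows a swap of this kind, so there is nothing in the measured data to anchor the size or direction of the change. Given this, the step from compound 1 to compound 4 in this assay is expected to be a number 3 percentage points higher from compound 1 to compound 4 (within the scatter), that is, nothing beyond the scatter. Compound 4 is estimated at 20%, with a range from 6% to 38%.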

Compound 4, percent growth inhibition at one concentration: 14%
Compound 4: middle estimate off by 6 percentage points, on the high side; the range from low to high includes it.
By their numbers in this assay, from the lowest: compounds 3, 4, 1 and 2 (each within the scatter of the next, the first and the last beyond it).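

In this assay, within the data shown here, the exchange of fluoro for chloro gives the first step that can be read (a number 3 percentage points lower from compound 1 to compound 4 (within the scatter)). At this position, on an aromatic carbon meta to a fused ring and para to a fused ring, fluoro and chloro therefore cannot be told apart at the one concentration tested. Nothing measured here bears on the reason for this result.

The compounds shown leave open whether a different group at this position, such as a methoxy group, a nitrile or an amine, would give a step beyond the scatter. They also leave open whether chloro and fluoro would remain indistinguishable on a longer chain than that of compound 1, or at another carbon of the same ring.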